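The source may report more compounds than this note shows. Statements on the series, on what has been measured and on what is new or still open speak of the compounds shown alone.

Compound 1 `Cc1cc(CC(=O)O)ccc1-c1noc(-c2ccc(C3CCCCC3)cc2)n1`: in a functional assay on CHO cells with sphingosine 1-phosphate receptor 4 (Homo sapiens) as the target, read by GTPgammaS binding (on this read-out lower numbers stand for an effect already at smaller amounts and higher numbers for an effect only at larger amounts of compound), compound 1 reaches only the limit > 10000 nM.
Compound 2 `Cc1cc(CCC(=O)O)ccc1-c1noc(-c2ccc(CC(C)C)nc2)n1`: in this assay compound 2 likewise reaches only the limit > 10000 nM.

Neither of these is a number; each marks the edge of what the assay reports. Compound 2 therefore stands where the whole measured set stands, since both values shown rest at the limit of > 10000 nM in this assay, at which 2 of the 2 values shown sit, and nothing in the data separates it from compound 1. Compound 3 `Cc1cc(CCC(=O)O)ccc1-c1noc(-c2ccc(OC(C)C)nc2)n1` follows from compound 2 by a single change, isopropoxy in place of isobutyl on an aromatic carbon. Among the compounds with values here, no step between measured compounds is available, so no size can be read from the data; with both reference compounds at the limit, the expectation for this assay is no step beyond the scatter in either direction. Compound 3 is accordingly expected to give about 20000 nM, between 3000 nM and 100000 nM, most probably again reported as a limit. The step that the limit leaves unreadable from compound 2 to compound 3 is estimated to stay within the scatter.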

Compound 3, half-maximal effective concentration: > 10000 nM
Compound 3: a limit, no number (the forecaster's own chance of this, stated with the estimate: 75%); the middle value is on the limit's open side.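

Within the data shown here, compound 3, like compound 2, ends in a limit and not a number, so no step between the two can be read in this assay: the limit of > 10000 nM in this assay, at which 3 of the 3 values shown sit. The compounds shown leave open how isopropoxy and isobutyl compare in this assay, and what would bring a measurable value there.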